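The compounds below may be only part of what the source reports. "The series", "measured", "known", "first", "only" and "open" are said of these compounds alone.

Working notes on the series, which measures displacement of a labelled ligand in an in vitro assay on HEK293 cells for displacement of a labelled ligand from adenosine receptor A2b (Homo sapiens); a higher number here means a weaker inhibitor, a lower number a stronger inhibitor.

Compound 1 `CCCn1c(=O)c2nc(-c3cnn(Cc4cc(C(F)(F)F)ccc4Cl)c3)[nH]c2n(CCC)c1=O` gives 22 nM in this assay, the lowest of the two numbers recorded. Among the compounds with values here, the nearest measured neighbour is compound 2 `CC(C)Cn1c(=O)c2nc(-c3cnn(Cc4cccc(F)c4)c3)[nH]c2n(CC(C)C)c1=O`, which gives 990 nM in this assay, a gap well beyond the scatter; compound 2 differs from compound 1 both in the chains on the shared core and in the group on the saturated chain carbon bound to an aromatic nitrogen, so the two values show only that compound 1 sits far lower. Compound 3 `CCCn1c(=O)c2nc(-c3cnn(-c4ccccc4)c3C(F)(F)F)[nH]c2n(CCC)c1=O` gives > 6600 nM in this assay, a limit of this assay and not a number. Its value sits at the limit of > 6600 nM in this assay, at which 1 of the 3 values shown sits. Within the data shown here, no pair of measured compounds differs in a single place, so no single step has been quantified.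

Compound 4 `CCCn1c(=O)c2nc(-c3cnn(Cc4c(F)cc(F)cc4F)c3)[nH]c2n(CCC)c1=O` has not yet been measured in this assay. It differs from compound 1 in one place: 2,4,6-trifluorophenyl in place of 2-chloro-5-(trifluoromethyl)phenyl on a saturated chain carbon bound to an aromatic nitrogen. Both groups are substituted aromatic rings of carbon only without hydrogen-bond donors or acceptors, and the change trades one halogen pattern for another. Among the measured compounds shown here, with no measured step to lean on, a modest weakening beyond the scatter is expected, the step from compound 1 to compound 4 estimated at a 3.2-fold higher number from compound 1 to compound 4 (0.50 log units; beyond the scatter). For compound 4 the estimated value in this assay is 70 nM, expected to lie between 20 nM and 250 nM.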

Compound 4, inhibition constant: 650 nM
The estimate for compound 4 lay 9.3-fold (0.97 log units) below the measured number; measured number outside the range, above it.
By their numbers in this assay, from the lowest: compound 1; then compounds 4 and 2 (each within the scatter of the next). At a limit, above all of these: compound 3.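

In this assay, 2,4,6-trifluorophenyl in place of 2-chloro-5-(trifluoromethyl)phenyl on a saturated chain carbon bound to an aromatic nitrogen gives a 30-fold higher number from compound 1 to compound 4 (1.47 log units; beyond the scatter), a large step and the first single-place step quantified in the series. Within the data shown here, the earlier compounds could show only that compound 1 sits far lower than its neighbours, whereas this pair holds the shared core and both propyl chains constant and ties a large change to this position alone. Both groups are six-membered aromatic rings of carbon only, with no hydrogen-bond donors or acceptors, so neither the ring type nor those counts separates the two values, and the low number of compound 1 depends on which substituents this ring carries. The values shown give no measured cause for this step.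

Among these compounds, with only one step at this position, it remains open whether the chlorine, the trifluoromethyl or the loss of the three fluorines accounts for the change. Also open, on these data alone, is how an unsubstituted phenyl, a pyridine ring or a 2-chlorophenyl would read at this place on the propyl-bearing core.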